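The source may hold more compounds than are shown below. What is called first, only, known or untested is meant among the compounds shown, and "the series" means these compounds.

Working notes on the series. In an ADME assay on WI-38 cells (Homo sapiens) for cytotoxicity, read by MTT assay, with a stated time of 72 h (on this read-out higher numbers stand for weaker inhibition and lower numbers for stronger inhibition), compound 1 (`O=C(CCc1cccc2c1B(O)OC2)Nc1ccccc1`) gives 30000 nM and compound 2 (`O=C(CCc1cccc2c1B(O)OC2)Nc1cccc(Br)c1`) gives 20000 nM with the bromo in place, and the step between them is a 1.5-fold lower number from compound 1 to compound 2 (0.18 log units; within the scatter) and so shows no readable shift. Compound 3 (`COc1cc(OC)cc(-c2cccc(NC(=O)CCc3cccc4c3B(O)OC4)c2)c1`) stands at 1700 nM as the lowest of the three numbers, with an 18-fold lower number from compound 1 to compound 3 (1.25 log units; beyond the scatter) and a 12-fold lower number from compound 2 to compound 3 (1.07 log units; beyond the scatter) as its two measured steps.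

Compound 4 (`O=C(CCc1cccc2c1B(O)OC2)Nc1cccc(-c2cccc(C(F)(F)F)c2)c1`) differs from compound 3 as follows (3-(trifluoromethyl)phenyl in place of 3,5-dimethoxyphenyl on an aromatic carbon): 3-(trifluoromethyl)phenyl in place of 3,5-dimethoxyphenyl on an aromatic carbon. Both groups hold one six-membered aromatic ring of carbon only, so the aromatic ring added in compound 3 stays. The two large steps bear on this only indirectly. Among the measured compounds shown here, they record what entry of 3,5-dimethoxyphenyl did, and no measured pair swaps one such group for another. Compound 4 is therefore expected to stay close to compound 3 at 1700 nM in this assay and not to return toward the numbers of the two simpler compounds, perhaps with a slight lean upward. The expected step is a 1.5-fold higher number from compound 3 to compound 4 (0.17 log units; within the scatter) and would lie within the scatter. For this assay compound 4 is estimated at 2500 nM with a range from 800 nM to 8000 nM as the expected spread.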

Compound 4, half-maximal inhibitory concentration: 23000 nM
Beside the measured number, compound 4's estimate is 9.2-fold (0.96 log units) below it; measured number above the stated range.
By their numbers in this assay, from the lowest: compound 3; then compounds 2, 4 and 1 (each within the scatter of the next).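

In this assay, exchanging one aryl group for another at this position is not a neutral change: a 14-fold higher number from compound 3 to compound 4 (1.13 log units; beyond the scatter) is a large step, so an added six-membered aromatic ring of carbon only does not by itself give the low number of compound 3. The 3-(trifluoromethyl)phenyl group instead leaves the series where the simpler compounds stand, with a 1.2-fold higher number from compound 2 to compound 4 (0.06 log units; within the scatter) and a 1.3-fold lower number from compound 1 to compound 4 (0.12 log units; within the scatter) both within the scatter, so of the added groups only 3,5-dimethoxyphenyl separates from the rest, and compound 4 goes against reading the added ring alone as the source of that separation. No supporting data on hand account for the gap between these two groups.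

As far as these compounds go, it remains open whether the low number of compound 3 depends on both methoxy groups, on one of them, or on oxygen substituents on the added ring more generally. An unsubstituted phenyl, a hydroxyphenyl or an aminophenyl at the same place would help separate these readings.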